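The compounds below may be only part of what the source reports. "The series", "measured", "known", "first", "only" and "open" are said of these compounds alone.

For the measured compounds named here, compound 2 `CN(C[C@@H]1CCCc2cc(S(=O)(=O)c3cccc(F)c3)ccc21)C(N)=O` gives 39.8 nM in an assay on isolated protein for displacement of a labelled ligand from 5-hydroxytryptamine receptor 6 (Homo sapiens) (a higher number here means a weaker inhibitor, a lower number a stronger inhibitor), the higher of the two numbers measured so far; compound 1 `O=C(NC[C@@H]1CCCc2cc(S(=O)(=O)c3cccc(F)c3)ccc21)[C@H]1CCCN1` gives 0.631 nM. Compound 3 `O=C(CO)NC[C@@H]1CCCc2cc(S(=O)(=O)c3cccc(F)c3)ccc21` is reached from compound 2 by ((hydroxymethyl)carbonyl)amino in place of carbamoyl(methyl)amino on a saturated chain carbon bound to a saturated ring carbon. Going by the values given here, the only measured step at the same place, a 63-fold higher number from compound 1 to compound 2 (1.80 log units; beyond the scatter), shows that changing this group can move the number a great deal. Compound 3 keeps a hydrogen on the chain nitrogen, as compound 1 does, so a lower number than compound 2 is expected, though not as low as compound 1. Compound 3 is therefore estimated at 10 nM, between 2 nM and 50 nM, a step of a 4.0-fold lower number from compound 2 to compound 3 (0.60 log units; beyond the scatter).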

Compound 3, inhibition constant: 0.1 nM
The estimate for compound 3 lay 100-fold (2.00 log units) above the measured number, and the stated range ends above it.
By their numbers in this assay, from the lowest: compound 3; then compound 1; then compound 2.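

The step of a 400-fold lower number from compound 2 to compound 3 (2.60 log units; beyond the scatter) shows that ((hydroxymethyl)carbonyl)amino on this saturated chain carbon gives a far lower number than carbamoyl(methyl)amino. The step of a 6.3-fold lower number from compound 1 to compound 3 (0.80 log units; beyond the scatter) shows that pyrrolidin-2-yl on the carbonyl carbon is not needed for a sub-nanomolar number, since hydroxymethyl in its place gives a lower one. Nothing measured here explains either step. Still open, on these data alone, is whether removing the methyl from carbamoyl(methyl)amino, giving a plain urea, would lower the number. Also open, as far as these compounds go, is how a methoxymethyl group or a longer chain, such as 2-hydroxyethyl, would behave on the carbonyl carbon.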